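This account rests on a few compounds, and the source may have more. Where it says the series, first, only, none or still open, it means among the compounds named here.

Compound 1, with the structure `COc1cc2c(Oc3ccc(NC(=O)c4cc(-c5ccccc5)ccn4)cc3F)ccnc2cc1OCCCN1CCN(C)CC1`, is the stronger of the two compounds measured here. In a functional assay on NCI-H460 cells (Homo sapiens) for cytotoxicity, read by MTT assay, with a stated time of 72 h (on this read-out higher numbers stand for weaker inhibition and lower numbers for stronger inhibition), compound 1 gives 91 nM, the lowest of the two numbers. Compound 2, with the structure `COc1cc2c(Oc3ccc(NC(=O)c4cc(-c5ccc(F)cc5)ccn4)cc3F)ccnc2cc1OCCCN1CCN(C)CC1`, differs only by a fluoro in place of hydrogen on an aromatic carbon, and in this assay compound 2 gives 430 nM; the step of a 4.7-fold higher number from compound 1 to compound 2 (0.67 log units; beyond the scatter) is a modest loss. Compound 3, with the structure `COc1cc2c(Oc3ccc(NC(=O)c4cc(-c5ccccc5)ccn4)cc3F)ccnc2cc1OCCCN1CCCCC1`, keeps the whole of compound 1 apart from the end of the side chain, where the change is piperidin-1-yl in place of 4-methylpiperazin-1-yl on a saturated chain carbon, three bonds along the chain from an oxygen on an aromatic ring. Within the data shown here, the one measured step concerns the aromatic fluoro on the other side of the molecule and does not touch the chain end, so no measured step bears directly on this change. Without a guiding step, the expectation for this assay is a step of a 1.2-fold higher number from compound 1 to compound 3 (0.08 log units; within the scatter) from compound 1 to compound 3, that is, no change beyond the scatter. Compound 3 is therefore estimated at 110 nM, with a range from 40 nM to 300 nM.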

Compound 3, half-maximal inhibitory concentration: 120 nM
Beside the measured number, compound 3's estimate is 1.1-fold (0.04 log units) below it; the measured number falls inside the stated range.
By their numbers in this assay, from the lowest: compounds 1 and 3 (each within the scatter of the next); then compound 2.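

In this assay, piperidin-1-yl in place of 4-methylpiperazin-1-yl at the end of the chain gives a 1.3-fold higher number from compound 1 to compound 3 (0.12 log units; within the scatter), so this read-out does not separate the two end groups. Among these compounds, at this place, then, the ring can go from two nitrogen atoms to one, and from two hydrogen-bond acceptors to one, without a change that can be told from the scatter, whereas the fluoro change elsewhere in the molecule gave a 4.7-fold higher number from compound 1 to compound 2 (0.67 log units; beyond the scatter) and remains the only step here beyond the scatter. No measurement at hand explains why these two end groups read alike, so the result describes this one pair and gives no reason for it.

The compounds shown leave open whether the same holds for other groups at the end of the chain, such as morpholin-4-yl, a simple dimethylamino group or a carboxylic acid, or for a chain shorter or longer than 3-(piperidin-1-yl)propyl. They also leave open whether compound 1 and compound 3 would stay this close on other cell lines, or whether piperidin-1-yl would read the same on a compound carrying the added fluoro of compound 2.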